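Oxan-4-yl replaces benzyl on a shared core

The source may hold more compounds than are shown below. What is called first, only, known or untested is meant among the compounds shown, and "the series" means these compounds.

Compound 1 `C=C[C@@H]1C[C@]1(NC(=O)[C@@H]1C[C@@H]2CN1C(=O)[C@H](C1CCCCC1)NC(=O)OCCC/C=C/c1ccc3ccnc(c3c1)O2)C(=O)NS(=O)(=O)C1CC1`: 482 ng.h/mL
Compound 2 `C=C[C@@H]1C[C@]1(NC(=O)[C@@H]1C[C@@H]2CN1C(=O)[C@H](Cc1ccccc1)NC(=O)OCCC/C=C/c1ccc3ccnc(c3c1)O2)C(=O)NS(=O)(=O)C1CC1`: 313 ng.h/mL

In an in vivo ADME assay on the whole organism (plasma, Rattus norvegicus, strain Sprague-Dawley) for pharmacokinetics, with a stated time of 4 h, at a dose of 5 mg/kg by the oral route (a higher number here means more compound in the circulation at the dose given, a lower number less compound in the circulation), compound 2 gives 313 ng.h/mL, and on these numbers it cannot be told apart from compound 1. Going by the values given here, the one measured step is a 1.5-fold lower number from compound 1 to compound 2 (0.19 log units; within the scatter), so the two compounds sit together inside the usual scatter of the measurement.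

The next compound is compound 3 `C=C[C@@H]1C[C@]1(NC(=O)[C@@H]1C[C@@H]2CN1C(=O)[C@H](C1CCOCC1)NC(=O)OCCC/C=C/c1ccc3ccnc(c3c1)O2)C(=O)NS(=O)(=O)C1CC1`, which carries oxan-4-yl in place of benzyl on a saturated ring carbon. Among the compounds with values here, only one measured step bears on this change, since it alters the group on the same carbon. That step, a 1.5-fold lower number from compound 1 to compound 2 (0.19 log units; within the scatter), stayed within the scatter, which gives a modest hint that this carbon tolerates a swap of groups in this assay. Within the data shown here, no measured compound carries oxan-4-yl, however, so the data point in neither direction and the range must stay wide.

The expected change is a 1.1-fold higher number from compound 2 to compound 3 (0.05 log units; within the scatter), with no shift beyond the scatter anticipated. For compound 3 the estimated value is 350 ng.h/mL, with an expected range from 130 ng.h/mL to 900 ng.h/mL.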

Compound 3, area under the concentration-time curve: 361 ng.h/mL
The estimate for compound 3 lay 1.0-fold (0.01 log units) below the measured number, and the stated range covers the measured number.
By their numbers in this assay, from the lowest: compounds 2, 3 and 1 (each within the scatter of the next).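

In this assay, putting oxan-4-yl on this saturated ring carbon gives a 1.2-fold higher number from compound 2 to compound 3 (0.06 log units; within the scatter), and comparing it with the cyclohexyl compound gives a 1.3-fold lower number from compound 1 to compound 3 (0.13 log units; within the scatter). Before this result, the only measured swap at this carbon was between two groups made of carbon alone. Oxan-4-yl brings an oxygen into the ring and, with it, a hydrogen-bond acceptor, yet all three compounds remain within the scatter of one another, so this read-out does not separate the aromatic benzyl group from either of the non-aromatic rings, with or without the oxygen. Nothing measured here offers an explanation for this result.

The compounds shown carry only six-membered rings at this carbon, so it remains open whether an amine, a carboxylic acid or a longer carbon chain there would move the number beyond the scatter. A single area under the curve after an oral dose also leaves open whether these compounds match in how much is absorbed and how quickly it is cleared, or only in the overall result.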